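Compound 3 to compound 4: methyl in place of amino

The source may report more compounds than this note shows. Statements on the series, on what has been measured and on what is new or still open speak of the compounds shown alone.

In a functional assay on MDA-MB-231 cells (Homo sapiens) for cytotoxicity, read by MTT assay, with a stated time of 48 h (a higher number here means a weaker inhibitor, a lower number a stronger inhibitor), compound 1 (`Fc1cccc(-c2nc(Nc3cccc(Cl)c3)c3cc(F)ccc3n2)c1`) gives > 50000 nM as a limit of the assay. Compound 2 (`Oc1ccccc1Nc1nc(-c2cccc(F)c2)nc2ccc(F)cc12`) gives > 50000 nM as a limit of the assay. Compound 3 (`Nc1cccc(Nc2nc(-c3cccc(F)c3)nc3ccc(F)cc23)c1`) gives > 50000 nM as a limit of the assay. Compound 3 therefore has no number of its own and stands with the other two at one shared limit (the limit of > 50000 nM in this assay, at which 3 of the 3 values shown sit).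

The change to compound 4 (`Cc1cccc(Nc2nc(-c3cccc(F)c3)nc3ccc(F)cc23)c1`) is methyl in place of amino on an aromatic carbon, meta to a large group (methyl in place of amino on an aromatic carbon). The closest measured change, amino in place of chloro on an aromatic carbon, is a step that the two limits leave unreadable from compound 1 to compound 3 and offers no size to carry over. The two changes on the nitrogen are a step that the two limits leave unreadable from compound 1 to compound 2 and a step that the two limits leave unreadable from compound 2 to compound 3 and offer none either.

Going by the values given here, no measured compound gives a number, so no direction can be argued. The expected move is a number no higher from compound 3 to compound 4 (the limit leaves the size open) in this assay with no readable size expected. For compound 4 the estimate is 50000 nM with an expected range from 15000 nM to 100000 nM and a further report as a limit is the likeliest outcome.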

Compound 4, half-maximal inhibitory concentration: > 50000 nM
Compound 4: only a limit was reported; the forecaster's own chance of this, stated with the estimate: 85%; the middle value lies on the limit itself.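

No new step can be read: compound 4 is reported only as a limit, as are compound 1, compound 2 and compound 3, so all steps to compound 4 stay unreadable and the series rests at one shared limit: the limit of > 50000 nM in this assay, at which 4 of the 4 values shown sit.

The compounds shown leave open what number any of them would carry in this assay, and so whether methyl, amino and chloro on that aromatic carbon differ at all.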